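Aryl ester exchange on the shared core: half-life notes

This account rests on a few compounds, and the source may have more. Where it says the series, first, only, none or still open, it means among the compounds named here.

In an ADME assay on a cell-free system (plasma, Homo sapiens) for metabolic stability, with Plasma (Rattus norvegicus) as the target, read by HPLC, at pH 7.4 (on this read-out lower numbers stand for a shorter-lived compound and higher numbers for a longer-lived compound), compound 3 `CCOc1cc(OCC)cc(C(=O)O[C@@H]2CO[C@H]3[C@@H]2OC[C@@H]3OC(=O)c2ccccc2OC(C)=O)c1` gives 0.0283 h, the highest of the three numbers measured. Its nearest neighbour is compound 2 `CC(=O)Oc1ccccc1C(=O)O[C@H]1CO[C@H]2[C@@H]1OC[C@H]2OC(=O)c1ccc([N+](=O)[O-])cc1`, which gives 0.0227 h, a step of a 1.2-fold higher number from compound 2 to compound 3 (0.10 log units; within the scatter). The furthest is compound 1 `CC(=O)Oc1ccccc1C(=O)O[C@H]1CO[C@H]2[C@@H]1OC[C@H]2OC(=O)c1ccccc1C`, which gives 0.0138 h, a step of a 2.1-fold higher number from compound 1 to compound 3 (0.31 log units; beyond the scatter). Between these two the step was a 1.6-fold higher number from compound 1 to compound 2 (0.22 log units; within the scatter).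

Compound 4 `CC(=O)Oc1ccccc1C(=O)O[C@H]1CO[C@H]2[C@@H]1OC[C@H]2OC(=O)c1ccc(CO[N+](=O)[O-])cc1` differs from compound 3 as follows: 4-((nitrooxy)methyl)phenyl in place of 3,5-diethoxyphenyl on a carbonyl carbon. Both measured steps that end at compound 3 bear on this change, since each also swaps the aryl group on the same carbonyl carbon: from 4-nitrophenyl the step was a 1.2-fold higher number from compound 2 to compound 3 (0.10 log units; within the scatter), from 2-methylphenyl it was a 2.1-fold higher number from compound 1 to compound 3 (0.31 log units; beyond the scatter). Three aryl variants thus span only a narrow band, with one modest step beyond the scatter. For compound 4 the step of a 1.3-fold lower number from compound 3 to compound 4 (0.11 log units; within the scatter) is therefore expected to be small, most likely a slightly lower number, and not clearly beyond the scatter. Compound 4 is estimated at 0.022 h, with a range from 0.01 h to 0.045 h.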

Compound 4, half-life: 0.04 h
The estimate for compound 4 lay 1.8-fold (0.26 log units) below the measured number, within the range that was stated.
By their numbers in this assay, from the lowest: compounds 1, 2, 3 and 4 (each within the scatter of the next, the first and the last beyond it).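

Exchanging the aryl group on this carbonyl carbon for 4-((nitrooxy)methyl)phenyl does not separate compound 4 from the two nearest variants in this assay: the readings are a 1.4-fold higher number from compound 3 to compound 4 (0.15 log units; within the scatter) and a 1.8-fold higher number from compound 2 to compound 4 (0.25 log units; within the scatter). The (nitrooxy)methyl in place of nitro thus leaves the number within the scatter. For the compounds shown here, only the exchange for 2-methylphenyl registers, at a 2.9-fold higher number from compound 1 to compound 4 (0.46 log units; beyond the scatter), a modest step and the only one ending at compound 4 that lies beyond the scatter; no measurement at hand accounts for any of these steps.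

On these data alone, whether hydroxymethyl in place of (nitrooxy)methyl on the aromatic carbon would keep the number in this band remains open. So does the outcome for an aryl group carrying an amine or a carboxylic acid, or for a straight alkyl chain on this carbonyl carbon.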